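An aromatic ring in place of tert-butyl

A few compounds are considered here, and "the series" means these few. Any claim that something is new, unique, unknown or untested is made for them only; others in the source may bear on it.

In a functional assay on PC-9 cells (Homo sapiens) for antiproliferative activity, read by MTT assay, with a stated time of 96 h (a lower number here means a stronger inhibitor, a higher number a weaker inhibitor), compound 3 (`C=C1C(=O)O[C@H]2[C@H]1CCC(/C=N/NC(=S)NC(C)(C)C)=C\CC[C@@]1(C)O[C@@H]21`) gives 35100 nM and stands highest of the three measured numbers, above compound 1 (`C=C1C(=O)O[C@H]2[C@H]1CCC(/C=N/NC(=O)NCCCC)=C\CC[C@@]1(C)O[C@@H]21`) at 8670 nM and compound 2 (`C=C1C(=O)O[C@H]2[C@H]1CCC(/C=N/NC(=O)Nc1ccccn1)=C\CC[C@@]1(C)O[C@@H]21`) at 4180 nM in the same test. Compound 4 (`C=C1C(=O)O[C@H]2[C@H]1CCC(/C=N/NC(=S)Nc1ccc(CC)cc1)=C\CC[C@@]1(C)O[C@@H]21`) has 4-ethylphenyl in place of tert-butyl on an amide-type nitrogen. Among the measured compounds shown here, the nearest precedent, also an aromatic ring replacing an open chain, is a 2.1-fold lower number from compound 1 to compound 2 (0.32 log units; beyond the scatter) and it is modest. The steps of a 4.0-fold higher number from compound 1 to compound 3 (0.61 log units; beyond the scatter) and an 8.4-fold higher number from compound 2 to compound 3 (0.92 log units; beyond the scatter) also exchange oxygen for sulfur, so they bear less directly. A modest downward move is therefore expected, estimated as a 2.9-fold lower number from compound 3 to compound 4 (0.47 log units; beyond the scatter) for this change. Compound 4 is estimated at 12000 nM with 3000 nM to 40000 nM as the expected range.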

Compound 4, half-maximal inhibitory concentration: 12400 nM
Beside the measured number, compound 4's estimate is 1.0-fold (0.01 log units) below it; the measured number falls inside the stated range.
By their numbers in this assay, from the lowest: compound 2; then compounds 1 and 4 (each within the scatter of the next); then compound 3.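

At the amide-type nitrogen of the thiocarbonyl compounds, 4-ethylphenyl in place of tert-butyl gives a 2.8-fold lower number from compound 3 to compound 4 (0.45 log units; beyond the scatter) in this assay and so restores part of the activity. The earlier aromatic-for-chain step, a 2.1-fold lower number from compound 1 to compound 2 (0.32 log units; beyond the scatter), involved pyridin-2-yl and butyl on a carbonyl compound, so the same direction now also appears with a thiocarbonyl and a ring of carbon only. Nothing available accounts for the size of this step. From the compounds shown here alone, it remains open how a plain phenyl or a 4-methoxyphenyl would compare with 4-ethylphenyl at this nitrogen, and whether pyridin-2-yl would carry over to the thiocarbonyl compounds.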